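This account rests on a few compounds, and the source may have more. Where it says the series, first, only, none or still open, it means among the compounds named here.

Measured compounds:
Compound 1, `CC1=NN(C(=O)c2ccc(C)cc2)C(c2cc(Br)ccc2O)C1`, in a functional assay on HepG2 cells (Homo sapiens) for cytotoxicity, read by MTT assay, with a stated time of 48 h (a lower number here means a stronger inhibitor, a higher number a weaker inhibitor), gives 23200 nM.
Compound 2, `CC1=NN(C(=O)c2ccc(C)cc2)C(c2cc(Br)cc(Br)c2O)C1`, in this assay gives "not active" (no number reported), with no number reported.
Compound 3, `O=C(c1ccccc1)N1N=C(c2cc3ccccc3oc2=O)CC1c1ccccc1`, in this assay gives 36600 nM.

Of the two compounds with a number in this assay, compound 3 has the higher one. Its nearest neighbour is compound 1, whose number is lower, but that gap lies within the usual scatter of the method, so the two cannot be told apart on these data. Compound 2 gave no number at all in this assay. Within the data shown here, no step between measured compounds that differ in one place is available, so nothing here shows how a single change moves the read-out.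

Compound 4, `CC(C)CNCC(=O)N1N=C(c2cc3ccccc3oc2=O)CC1c1ccccc1`, has not yet been measured. It differs from compound 3 in one place: (isobutylamino)methyl in place of phenyl on a carbonyl carbon. The change sits on the carbonyl carbon whose other neighbour is the amide-type nitrogen in the ring; cut one bond further out it reads benzoyl to ((isobutylamino)methyl)carbonyl.

Among the measured compounds shown here, with no measured step to lean on and all numbers so far weak and close together, the step of a 1.1-fold higher number from compound 3 to compound 4 (0.04 log units; within the scatter) is expected to stay within the scatter, or at most drift toward a weaker result. Compound 4 is therefore estimated at 40000 nM in this assay, with a range from 15000 nM to 110000 nM.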

Compound 4, half-maximal inhibitory concentration: 9970 nM
For compound 4 the middle estimate is 4.0-fold (0.60 log units) above the measured one; the measured number lies below the stated range.
By their numbers in this assay, from the lowest: compound 4; then compounds 1 and 3 (each within the scatter of the next).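

In this assay, among these compounds, the carbonyl carbon attached to the amide-type nitrogen in the ring is the first place in this set where a single change can be read, and the read-out responds to it (a 3.7-fold lower number from compound 3 to compound 4 (0.56 log units; beyond the scatter)), a modest step with (isobutylamino)methyl in place of phenyl. In this pair, therefore, a phenyl on that carbonyl carbon is not required for activity, and a chain with no ring and one nitrogen gives the lower number. Nothing available here explains the shift.

This single step cannot separate the loss of the phenyl ring from the arrival of the amine nitrogen, and a plain alkyl chain such as isopentyl, a tertiary amine such as a dimethylamino group, or a carboxylic acid at the same place would be needed to tell these apart. On these data alone, it also remains open whether the same exchange would lower the number on the core of compound 1, or whether the step holds only on the core shared by compound 3 and compound 4.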